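The source may hold more compounds than are shown below. What is called first, only, known or untested is meant among the compounds shown, and "the series" means these compounds.

Measured so far:
compound 1, `COc1cc(OC)c(OC)cc1/C=C/COC(=O)/C=C/c1cc(OC)c(OC)c(OC)c1OC`: 50%
compound 2, `COc1cc(OC)c(OC)cc1/C=C/COC(=O)/C=C/c1cccc(Br)c1`: 50%
compound 3, `COc1cc(OC)c(OC)cc1/C=C/COC(=O)/C=C/c1ccccc1Cl`: 50%

All three values come from a functional assay on the whole organism (strain Kunming) with Mus musculus as the target, with a stated time of 0.5 h, at a dose of 300 mg/kg by the intraperitoneal route; a higher number here means a weaker effect of the compound at the dose given, a lower number a stronger effect. Compound 3 stands level with compound 1 and compound 2 at the digits reported; the gap to either of them lies within the scatter. Going by the values given here, the one step measured, no change at the digits printed from compound 2 to compound 3 (within the scatter), replaces one group by another at the same place on the chain and leaves the read-out unchanged.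

Compound 4, `COc1cc(OC)c(OC)cc1/C=C/COC(=O)/C=C/c1ccc(Cl)cc1`, is not yet measured. Its difference from compound 3 is 4-chlorophenyl in place of 2-chlorophenyl on a double-bonded chain carbon bound to a double-bonded chain carbon. Among the compounds with values here, the only step that bears on it is no change at the digits printed from compound 2 to compound 3 (within the scatter): a change of the same kind, at the same place, that produced nothing beyond the scatter. Compound 1, which carries a different group at that place, also sits at the same level. No change beyond the scatter is therefore expected from compound 3 to compound 4, no change at the digits printed from compound 3 to compound 4 (within the scatter). For compound 4 the estimate in this assay is 50%, expected to fall between 35% and 65%.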

Compound 4, a percentage reported as activity, at one dose (the size of the read-out at that dose, not a potency): 50%
Estimate against measurement, compound 4: no gap at the digits printed; low and high end bracket the measured number.
By their numbers in this assay, from the lowest: compounds 1, 2, 3 and 4 (each within the scatter of the next).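

In this assay, the series now holds a step that alters only where the chlorine sits on the phenyl, 4-chlorophenyl in place of 2-chlorophenyl, and it gives no change at the digits printed from compound 3 to compound 4 (within the scatter). The read-out at this place on the chain thus does not separate these two chlorophenyl isomers, and the exchange of 3-bromophenyl for 4-chlorophenyl likewise gives no change at the digits printed from compound 2 to compound 4 (within the scatter). No evidence is available that would account for this flat read-out.

Whether an aryl amine, a carboxylic acid or a longer chain at this place would shift the read-out remains open, as the groups shown here are halogenated phenyls and the methoxy-substituted phenyl of compound 1. Being a read-out at one dose, these numbers show the size of the effect at that dose only and leave open whether any of the compounds would give a stronger or weaker effect at another dose.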